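Series notes: hydroxy in place of tert-butyl

The compounds below may be only part of what the source reports. "The series", "measured", "known", "first", "only" and "open" are said of these compounds alone.

Measured so far:
- compound 1, `O=C(N/N=C/c1ccc(O)cc1)c1ccc(O)cc1`: 54.4%
- compound 2, `COc1ccc(/C=C/C=N/NC(=O)c2ccc(C(C)(C)C)cc2)cc1`: 5.6%

In a physicochemical assay, read by spectrophotometry, with a stated time of 60 min, tested at 300 uM (on this read-out higher numbers stand for a stronger effect at the one concentration tested and lower numbers for a weaker effect), compound 2 stands lowest of the two numbers. Its nearest neighbour is compound 1, whose value in this assay lies well above that of compound 2, a gap beyond the usual scatter. Within the data shown here, compound 1 and compound 2 differ in more than one place, so no single step between them can be read.

Compound 3, `COc1ccc(/C=C/C=N/NC(=O)c2ccc(O)cc2)cc1`, is not yet measured. It differs from compound 2 in one place: hydroxy in place of tert-butyl on an aromatic carbon. Among the measured compounds shown here, no measured pair shows this exact change on its own. For the measured compounds named here, the only guide is that compound 1, carrying hydroxy groups, reaches 54.4% in this assay, while compound 2 gives 5.6%; part of that gap may belong to the change in question. An upward step of a number 22.4 percentage points higher from compound 2 to compound 3 (beyond the scatter) is therefore expected, beyond the scatter but not reaching compound 1. For compound 3 the estimate in this assay is 28%, with a range from 8% to 52%.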

Compound 3, a percentage reported as inhibition, at one concentration (the size of the read-out at that concentration, not a potency): 2.6%
The estimate for compound 3 lay 25.4 percentage points above the measured number, and the stated range ends above it.
By their numbers in this assay, from the lowest: compounds 3 and 2 (each within the scatter of the next); then compound 1.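

In this assay, among these compounds, hydroxy in place of tert-butyl on an aromatic carbon, para to a large group, gives a number 3 percentage points lower from compound 2 to compound 3 (within the scatter), the first step that can be read for a single place. At this position, a carbon-only group and a group with a hydrogen-bond donor and acceptor therefore cannot be told apart on this read-out, with the rest of the structure held as in compound 2 and compound 3. No measurement at hand gives a reason for this result.

Still open, as far as these compounds go, is whether any other group at this position, such as an amine or a carboxylic acid, would separate from these two. Among the compounds shown here, also open is what the methoxy group and the alkene link contribute on their own, as no single-place step covers either.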